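A few compounds are considered here, and "the series" means these few. Any claim that something is new, unique, unknown or untested is made for them only; others in the source may bear on it.

Measured compounds:
Compound 1 `CNC(=O)c1cc(Oc2ccc3nc(Nc4ccccc4)ncc3c2)ccn1` — in a physicochemical assay for solubility, at pH 7 (a lower number here means a less soluble compound, a higher number a more soluble compound), compound 1 gives < 1000 nM, which is a limit of the assay and not a number.
Compound 2 `CCc1ccccc1Nc1ncc2cc(Oc3ccnc(C(=O)NC)c3)ccc2n1` — in this assay compound 2 gives < 1000 nM, again a limit of the assay.

Compound 2 therefore stands only at a limit in this assay, with no number of its own. Within the data shown here, the one measured step, from compound 1 to compound 2, is a step that the two limits leave unreadable from compound 1 to compound 2: the ethyl in place of hydrogen on an aromatic carbon cannot be read in size, because both compounds sit at the limit of < 1000 nM in this assay, at which 2 of the 2 values shown sit.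

Compound 3 `CNC(=O)c1cc(Oc2ccc3nc(Nc4cccc(Br)c4)ncc3c2)ccn1` is the next compound, not yet measured. It differs from compound 2 by 3-bromophenyl in place of 2-ethylphenyl on a nitrogen on an aromatic ring. Among the measured compounds shown here, no measured step bears on this change; the only step available, from compound 1 to compound 2, is itself unreadable. With both neighbours at the limit, the step from compound 2 to compound 3 in this assay is expected to be a step that the limit leaves unreadable from compound 2 to compound 3, most likely leaving compound 3 at the same limit. The estimate for compound 3 in this assay is 500 nM, within a range from 50 nM to 3000 nM.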

Compound 3, solubility: < 1000 nM
Compound 3 ended at the assay's limit (the forecaster's own chance of this, stated with the estimate: 75%); the middle value is on the limit's open side.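

In this assay compound 3 gives < 1000 nM as a limit of the assay and not a number. Among these compounds, no step among compound 1, compound 2 and compound 3 can be read in size: the limit of < 1000 nM in this assay, at which 3 of the 3 values shown sit. The compounds shown leave open how soluble each of the three actually is, and whether the ethyl or bromo changes alter that at all.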